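A few compounds are considered here, and "the series" means these few. Any claim that something is new, unique, unknown or untested is made for them only; others in the source may bear on it.

Compound 2 `Cc1c(Cc2ccc(Cl)cc2)c(=O)oc2cc(OCC(O)CN3CCC(C(N)=O)CC3)ccc12` is tested in an ADME assay on A549 cells (Homo sapiens) for cytotoxicity, read by CellTiter-Glo (on this read-out lower numbers stand for higher toxicity in this test and higher numbers for lower toxicity in this test), and gives 40000 nM. Compound 1 `Cc1c(Cc2cccc(F)c2)c(=O)oc2cc(OCC(O)CN3CCC(C(N)=O)CC3)ccc12` gives 53300 nM in this assay, and the step of a 1.3-fold lower number from compound 1 to compound 2 (0.12 log units; within the scatter) leaves the two within scatter of each other. Compound 3 `COc1ccccc1-c1ccc(Cc2c(C)c3ccc(OCC(O)CN4CCC(C(N)=O)CC4)cc3oc2=O)cc1` carries 2-methoxyphenyl in place of chloro on an aromatic carbon. Among the compounds with values here, the single measured step, a 1.3-fold lower number from compound 1 to compound 2 (0.12 log units; within the scatter), is the only one that bears on this change, and it was small; it involves a far smaller exchange on the same ring than the one that forms compound 3, so it offers little guide. Compound 3 is therefore expected to show a step of a 1.1-fold lower number from compound 2 to compound 3 (0.06 log units; within the scatter), with an estimate of 35000 nM ranging from 12000 nM to 100000 nM.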

Compound 3, half-maximal cytotoxic concentration: 91600 nM
The estimate for compound 3 lay 2.6-fold (0.42 log units) below the measured number; the range from low to high includes it.
By their numbers in this assay, from the lowest: compounds 2, 1 and 3 (each within the scatter of the next, the first and the last beyond it).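

In this assay, within the data shown here, the exchange of chloro for 2-methoxyphenyl on the aromatic carbon gives the first step that lies beyond the scatter (a 2.3-fold higher number from compound 2 to compound 3 (0.36 log units; beyond the scatter)). This position therefore carries a far larger group with an added aromatic ring, and the number moves towards lower toxicity in this test rather than falling. No measurement to hand accounts for this step.

On these data alone, whether the rise depends on the added ring or on its methoxy group stays open. So does whether an amine or a carboxylic acid at this aromatic carbon would move the number the same way.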